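The compounds below may be only part of what the source reports. "The series", "measured", "known", "first", "only" and "open" are said of these compounds alone.

Compound 1 `N#Cc1c(-c2nnc(-c3nn(-c4ccccc4)c(-c4ccccc4)c3C#N)c3nn(-c4ccccc4)cc23)nn(-c2ccccc2)c1-c1ccccc1` and compound 2 `N#Cc1c(-c2nnc(-c3nn(-c4ccccc4)c(-c4ccccc4)c3C#N)c3nn(-c4ccc(Cl)cc4)cc23)nn(-c2ccccc2)c1-c1ccccc1` share a core and differ in one spot: chloro in place of hydrogen on an aromatic carbon. In a functional assay on MDA-MB-231 cells (Homo sapiens) for inhibition, read by sulforhodamine B assay, with a stated time of 48 h (on this read-out higher numbers stand for weaker inhibition of growth and lower numbers for stronger inhibition of growth), compound 1 gives 52400 nM, while compound 2 gives 7900 nM; this step, a 6.6-fold lower number from compound 1 to compound 2 (0.82 log units; beyond the scatter), is the only measured effect of that change here. Compound 3 `N#Cc1c(-c2nnc(-c3ccccc3)c3nn(-c4ccccc4)cc23)nn(-c2ccccc2)c1-c1ccccc1` has a smaller core; how it differs from the core of compound 1 is not broken down here. In this assay compound 3 gives 8840 nM. Compound 4 `N#Cc1c(-c2nnc(-c3ccccc3)c3nn(-c4ccc(Cl)cc4)cc23)nn(-c2ccccc2)c1-c1ccccc1` is not yet measured and differs from compound 3 by the same change, (chloro in place of hydrogen on an aromatic carbon), at the same kind of place. The step from compound 3 to compound 4 is expected to be a 2.9-fold lower number from compound 3 to compound 4 (0.47 log units; beyond the scatter), a somewhat smaller shift than the earlier one, since the change has been seen only once and on a different core. Compound 4 is therefore estimated at 3000 nM, with a likely range from 1200 nM to 8000 nM.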

Compound 4, concentration for 50% growth inhibition: 6420 nM
Estimate against measurement, compound 4: 2.1-fold (0.33 log units) below; low and high end bracket the measured number.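

On the core of compound 3, going from phenyl to 4-chlorophenyl gives a 1.4-fold lower number from compound 3 to compound 4 (0.14 log units; within the scatter) and so cannot be told apart from repeat-to-repeat noise. Set beside the earlier step, the same change does not carry over evenly between the two cores in this assay: the same change on two cores in this assay, a 6.6-fold lower number (0.82 log units; beyond the scatter) from compound 1 to compound 2 and a 1.4-fold lower number (0.14 log units; within the scatter) from compound 3 to compound 4, 4.8-fold (0.68 log units) apart, beyond the scatter of two such steps. A shift seen on one core therefore cannot be assumed on another in this series, but two pairs do not show why the cores differ or how a third core would respond.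

The compounds shown carry only hydrogen or chloro at this spot, so the effect of a fluoro, a methoxy or an amine there remains open.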